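Swapping the Cyclobutyl Amide for a Methoxymethyl Amide

The source may hold more compounds than are shown below. What is called first, only, known or untested is meant among the compounds shown, and "the series" means these compounds.

Compound 1, `CCCC(=O)Nc1c(C(O)(C(F)(F)F)C(F)(F)F)ccc2ccccc12`: in an assay on LtK cells with ATP-sensitive inward rectifier potassium channel 11 (Homo sapiens) as the target (a higher number here means that more compound is needed for the effect, a lower number that less compound is needed), compound 1 gives 131 nM.
Compound 2, `CC(C)=CC(=O)Nc1c(C(O)(C(F)(F)F)C(F)(F)F)ccc2ccccc12`: compound 2 gives 46 nM.
Compound 3, `O=C(Nc1c(C(O)(C(F)(F)F)C(F)(F)F)ccc2ccccc12)C1CCC1`: compound 3 gives 45 nM.

Compound 3 carries the lowest of the three numbers, yet the step of a 1.0-fold lower number from compound 2 to compound 3 (0.01 log units; within the scatter) is within the scatter, so compound 2 and compound 3 cannot be told apart; only compound 1 stands clearly apart, as the step of a 2.9-fold lower number from compound 1 to compound 3 (0.46 log units; beyond the scatter) shows.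

Compound 4, `COCC(=O)Nc1c(C(O)(C(F)(F)F)C(F)(F)F)ccc2ccccc12`, differs from compound 3 in one place: methoxymethyl in place of cyclobutyl on a carbonyl carbon. For the measured compounds named here, no measured step introduces an oxygen into this group, so nothing directly matches the change. What the data do show is that moving from the propyl of compound 1 to a branched or ring-shaped group lowered the number modestly, in the steps of a 2.8-fold lower number from compound 1 to compound 2 (0.45 log units; beyond the scatter) and a 2.9-fold lower number from compound 1 to compound 3 (0.46 log units; beyond the scatter). Methoxymethyl is neither branched nor a ring, and it is shorter than propyl, so the gain seen for compound 2 and compound 3 is not expected to carry over.

The step from compound 3 to compound 4 is therefore estimated as a 3.3-fold higher number from compound 3 to compound 4 (0.52 log units; beyond the scatter), a rise in the number of roughly the size seen against compound 1. Compound 4 is expected to give about 150 nM in this assay, within a range from 50 nM to 500 nM.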

Compound 4, half-maximal effective concentration: 213 nM
For compound 4 the middle estimate is 1.4-fold (0.15 log units) below the measured one; low and high end bracket the measured number.
By their numbers in this assay, from the lowest: compounds 3 and 2 (each within the scatter of the next); then compounds 1 and 4 (each within the scatter of the next).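

In this assay, this position on the carbonyl carbon does not treat all small groups alike: methoxymethyl gives a clearly higher number than cyclobutyl (a 4.7-fold higher number from compound 3 to compound 4 (0.68 log units; beyond the scatter)) and than 2-methylprop-1-en-1-yl (a 4.6-fold higher number from compound 2 to compound 4 (0.67 log units; beyond the scatter)), and both steps lie beyond the scatter. Exchanging the ethyl part of the propyl chain for methoxy leaves compound 4 indistinguishable from compound 1 (a 1.6-fold higher number from compound 1 to compound 4 (0.21 log units; within the scatter)), so among these four compounds the two unbranched, ring-free groups sit together, apart from the branched group of compound 2 and the ring of compound 3. No measurement shown here explains why the numbers fall this way.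

These compounds cannot separate the effect of the oxygen from the loss of the ring or the branch, and a ring that itself contains an oxygen, such as tetrahydrofuranyl, would test those two features together. As far as these compounds go, it also remains open how this position responds to an amine such as dimethylaminomethyl, or to a longer carbon chain such as pentyl.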